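Cyano for hydroxy on the phenyl of compound 2

The compounds below may be only part of what the source reports. "The series", "measured", "known", "first", "only" and "open" are said of these compounds alone.

Measured compounds:
compound 1 `CCCn1c(=O)n(C)c(=O)c2[nH]c(-c3ccccc3)nc21` gives 6.3 nM in an assay on Cortex for displacement of a labelled ligand from adenosine receptor A1 (Rattus norvegicus); a lower number here means a stronger inhibitor, a higher number a weaker inhibitor
compound 2 `CCCn1c(=O)n(C)c(=O)c2[nH]c(-c3ccc(O)cc3)nc21` gives 2.54 nM in this assay
compound 3 `CCCn1c(=O)c2nc(-c3ccc(C#N)cc3)[nH]c2n(CCC)c1=O` gives 4.48 nM in this assay

Compound 2 carries the lowest number of the three in this assay. Compound 3 comes nearest, with a number that lies within the scatter of compound 2, so the two cannot be ordered. Compound 1 stands furthest away; the step of a 2.5-fold lower number from compound 1 to compound 2 (0.39 log units; beyond the scatter) is modest but beyond the scatter.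

The unmeasured compound 4 `CCCn1c(=O)n(C)c(=O)c2[nH]c(-c3ccc(C#N)cc3)nc21` is compound 2 with cyano in place of hydroxy on an aromatic carbon. Among the compounds with values here, only one measured step touches the same aromatic carbon, a 2.5-fold lower number from compound 1 to compound 2 (0.39 log units; beyond the scatter), and it concerns hydroxy against hydrogen, not cyano against hydroxy. Compound 3 carries the cyano group on a core with two propyl chains rather than one, and its number and that of compound 2 lie within the scatter of each other, so they show no direction for this exchange.

Compound 4 is therefore expected to stay close to compound 2, with the step of a 1.6-fold higher number from compound 2 to compound 4 (0.20 log units; within the scatter) estimated to fall within the scatter. The estimate for compound 4 in this assay is 4 nM, with a range from 1.5 nM to 10 nM.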

Compound 4, inhibition constant: 13.9 nM
The estimate for compound 4 lay 3.5-fold (0.54 log units) below the measured number; measured number above the stated range.
By their numbers in this assay, from the lowest: compounds 2, 3 and 1 (each within the scatter of the next, the first and the last beyond it); then compound 4.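

In this assay the aromatic carbon para to a large group now proves sensitive in both directions, and the exchange of hydroxy for cyano gives a 5.5-fold higher number from compound 2 to compound 4 (0.74 log units; beyond the scatter) as the largest step seen at this place. Set against hydrogen, cyano moves the number the opposite way from hydroxy, with a 2.2-fold higher number from compound 1 to compound 4 (0.34 log units; beyond the scatter) against a 2.5-fold lower number from compound 1 to compound 2 (0.39 log units; beyond the scatter) for hydroxy, so that on the shared core the numbers run from hydroxy through hydrogen to cyano, with each of these steps beyond the scatter. Nothing at hand explains this order.

From the compounds shown here alone, whether an amine, a methoxy group or a carboxylic acid on this carbon would fall on the side of hydroxy or on the side of cyano remains open. Also open is whether the same order holds on the core with two propyl chains, where compound 3 carries cyano but no partner with hydrogen or hydroxy on this carbon is shown.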